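The compounds below may be only part of what the source reports. "The series", "measured", "known", "first", "only" and "open" are said of these compounds alone.

Working notes on the series.

The shared core is carried unchanged through the set; compound 1 `O=C(Nc1cccc(-c2oc3cc(-c4ccc(F)cc4)ccc3c(=O)c2O)c1)c1ccc(C(F)(F)F)cc1` and compound 2 `O=C(Nc1cccc(-c2oc3cc(-c4ccc(F)cc4)ccc3c(=O)c2O)c1)c1ccc(Br)cc1` differ only in the group on the carbonyl carbon of the amide. In a functional assay on GTL 16 cells for antiproliferative activity against GTL 16 cell line (Homo sapiens), read by CCK-8 assay, with a stated time of 72 h (on this read-out lower numbers stand for stronger inhibition and higher numbers for weaker inhibition), compound 1 gives 33000 nM, and compound 2 gives 25400 nM. Within the data shown here, the single measured step, a 1.3-fold lower number from compound 1 to compound 2 (0.11 log units; within the scatter), leaves the two numbers within the scatter of each other, so compound 2 stands beside compound 1 on this assay rather than apart from it.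

Compound 3 `COc1cccc(C(=O)Nc2cccc(-c3oc4cc(-c5ccc(F)cc5)ccc4c(=O)c3O)c2)c1` is not yet measured. Its change from compound 2 is 3-methoxyphenyl in place of 4-bromophenyl on a carbonyl carbon. Among the measured compounds shown here, the only step on record, bromo for trifluoromethyl on the same ring, bears on it just as a change of the group on the amide carbonyl; it was a 1.3-fold lower number from compound 1 to compound 2 (0.11 log units; within the scatter) and did not leave the scatter. For the measured compounds named here, no measured pair shows a methoxyphenyl, and no pair moves a substituent around the ring, so nothing here points to a shift in either direction.

The step from compound 2 to compound 3 is therefore expected to be a 1.0-fold lower number from compound 2 to compound 3 (0.01 log units; within the scatter), within the scatter. For compound 3 the estimate in this assay is 25000 nM, with a range from 8000 nM to 80000 nM.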

Compound 3, half-maximal inhibitory concentration: 12500 nM
The estimate for compound 3 lay 2.0-fold (0.30 log units) above the measured number; low and high end bracket the measured number.
By their numbers in this assay, from the lowest: compound 3; then compounds 2 and 1 (each within the scatter of the next).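

On the group at the carbonyl carbon of the amide, the position now shows movement beyond the scatter in this assay: 3-methoxyphenyl in place of 4-bromophenyl gives a 2.0-fold lower number from compound 2 to compound 3 (0.31 log units; beyond the scatter), and 3-methoxyphenyl in place of 4-(trifluoromethyl)phenyl gives a 2.6-fold lower number from compound 1 to compound 3 (0.42 log units; beyond the scatter), both modest, whereas bromo in place of trifluoromethyl did not leave the scatter. Each of these two changes alters the substituent and its place on the ring together, and 3-methoxyphenyl also holds 1 hydrogen-bond acceptor where 4-bromophenyl holds 0, so the step cannot be assigned to any one of these differences. Nothing measured on these compounds speaks to what lies behind the step.

Still open, on these data alone, is whether the methoxy group or its place on the ring carries the step, a question that 4-methoxyphenyl and 3-bromophenyl at the same carbonyl carbon would separate. Also open, as far as these compounds go, is how far this position tolerates other groups, such as an unsubstituted phenyl, an amine or a carboxylic acid on the ring, and whether any of them moves the number further than the modest steps seen here.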